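This account rests on a few compounds, and the source may have more. Where it says the series, first, only, none or still open, it means among the compounds named here.

Three compounds have so far been measured in a functional assay on MDA-MB-231 cells (Homo sapiens) for cytotoxicity, read by MTT assay, with a stated time of 48 h; a higher number here means a weaker inhibitor, a lower number a stronger inhibitor:

Compound 1 `O=C(O)c1ccc(-n2cc(CO[C@H]3CC(=O)[C@@H]4OC[C@H]3O4)nn2)cc1` gives 23200 nM.
Compound 2 `COc1ccc(Cn2cc(CO[C@H]3CC(=O)[C@@H]4OC[C@H]3O4)nn2)cc1` gives 34800 nM.
Compound 3 `O=C1C[C@H](OCc2cc(-c3ccccc3)no2)[C@H]2CO[C@@H]1O2` gives 21900 nM.

All three share the same bicyclic core and differ only in the group attached through the ether-linked methylene. In this assay the number for compound 3 is the lowest of the three, but its gaps to compound 1 and to compound 2 both fall within the usual scatter of repeated measurements, so the three compounds cannot be told apart on these numbers.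

Compound 4 `O=C1C[C@H](OCc2cc(-c3ccc(Cl)cc3)no2)[C@H]2CO[C@@H]1O2` has not yet been measured. It differs from compound 3 by one change: chloro in place of hydrogen on an aromatic carbon. Going by the values given here, no pair among the measured compounds shows this kind of change, so there is nothing here to say how large its effect should be. The expectation is a small step from compound 3 to compound 4, a 1.3-fold lower number from compound 3 to compound 4 (0.11 log units; within the scatter), toward a slightly lower number but not beyond the scatter. Compound 4 is therefore estimated at 17000 nM, with a range from 6000 nM to 45000 nM.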

Compound 4, half-maximal inhibitory concentration: 17900 nM
Beside the measured number, compound 4's estimate is 1.1-fold (0.02 log units) below it; the range from low to high includes it.
By their numbers in this assay, from the lowest: compounds 4, 3, 1 and 2 (each within the scatter of the next).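

Going by these compounds alone, for the first time, a single change can be read on its own: going from phenyl to 4-chlorophenyl gives a 1.2-fold lower number from compound 3 to compound 4 (0.09 log units; within the scatter) in this assay. A chlorine atom can therefore replace hydrogen on this aromatic carbon, para to a large group, with no difference that this assay can separate from the scatter of repeated measurements. Nothing available bears on why this step has the size it has.

As far as these compounds go, one small atom at one place says little about the position as a whole, so it remains open whether a larger or very different group, such as an amine or a trifluoromethyl group, would move the number beyond the scatter. From the compounds shown here alone, it is equally open whether chloro on another carbon of the same ring would behave as it does here.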